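A few compounds are considered here, and "the series" means these few. Any claim that something is new, unique, unknown or untested is made for them only; others in the source may bear on it.

In an assay on isolated protein for displacement of a labelled ligand from prostaglandin E2 receptor EP3 subtype (Homo sapiens), read by scintillation counting, with a stated time of 2 h (a lower number here means a stronger inhibitor, a higher number a weaker inhibitor), two compounds of a shared core have been measured. Compound 1 `COc1ccc(Cl)cc1S(=O)(=O)NC(=O)NC/C=C1\CCCc2cnn(Cc3ccc(Cl)cc3Cl)c21` gives 3 nM. Compound 2 `O=C(NC/C=C1\CCCc2cnn(-c3ccc(C(F)(F)F)cc3)c21)NS(=O)(=O)c1cc(Cl)c(Cl)s1` gives 0.4 nM, the lower of the two numbers, and the gap to compound 1 lies beyond the usual scatter of this assay, so compound 2 stands as the stronger binder of the pair.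

Compound 3 `O=C(NC/C=C1\CCCc2cnn(Cc3ccc(Cl)cc3Cl)c21)NS(=O)(=O)c1cc(Cl)c(Cl)s1` has not yet been measured. It differs from compound 2 in one place: 2,4-dichlorobenzyl in place of 4-(trifluoromethyl)phenyl on an aromatic nitrogen. For the measured compounds named here, no measured pair isolates this single change, so there is no directly counted step to lean on. Compound 1 carries the same 2,4-dichlorobenzyl group and still gives 3 nM, which shows that this group is compatible with a low number in this assay, although compound 1 also differs from compound 3 elsewhere.

The step from compound 2 to compound 3 is therefore expected to be small, probably within the scatter or a modest rise, as a 2.5-fold higher number from compound 2 to compound 3 (0.40 log units; beyond the scatter) expresses. Compound 3 is estimated at 1 nM, with a likely range from 0.3 nM to 4 nM.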

Compound 3, inhibition constant: 0.5 nM
The estimate for compound 3 lay 2.0-fold (0.30 log units) above the measured number; measured number inside the range.
By their numbers in this assay, from the lowest: compounds 2 and 3 (each within the scatter of the next); then compound 1.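

In this assay, replacing 4-(trifluoromethyl)phenyl with 2,4-dichlorobenzyl on the aromatic nitrogen gives a 1.3-fold higher number from compound 2 to compound 3 (0.10 log units; within the scatter) and so leaves no readable difference between these two groups at this position. With 2,4-dichlorobenzyl held in place, 4,5-dichlorothiophen-2-yl in place of 5-chloro-2-methoxyphenyl on the sulfonyl sulfur gives a 6.0-fold lower number from compound 1 to compound 3 (0.78 log units; beyond the scatter) in this assay; compound 1 and compound 2 differ in two places and could not separate these changes, whereas these two steps place the change beyond the scatter at the sulfonyl sulfur. No measurement here bears on the reason for either step.

Going by these compounds, both groups seen on the aromatic nitrogen carry a six-membered aromatic ring of carbon only, so it remains open whether a plain butyl chain, or a chain ending in an amine or a carboxylic acid, would give a similar number there. On these data alone, it is also open whether the step at the sulfonyl sulfur would be of similar size with 4-(trifluoromethyl)phenyl on the nitrogen instead of 2,4-dichlorobenzyl.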